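The compounds below may be only part of what the source reports. "The series", "measured", "known", "first", "only" and "open" are said of these compounds alone.

Compound 1 `CCCOc1c(O)cc2oc(-c3ccccc3)cc(=O)c2c1O`: 2000 nM
Compound 2 `CCCOc1c(OC)cc2oc(-c3ccccc3)cc(=O)c2c1O`: 1200 nM
Compound 3 `CCCCCCOc1cc2oc(-c3ccccc3)cc(=O)c2c(O)c1OCCCCCC`: 1000 nM

In a functional assay on KB 3-1 cells (Homo sapiens), with a stated time of 1 h (on this read-out higher numbers stand for an effect only at larger amounts of compound and lower numbers for an effect already at smaller amounts), compound 1 gives 2000 nM and compound 2 gives 1200 nM. The two differ by methyl in place of hydrogen on an oxygen on an aromatic ring, and that change produced a 1.7-fold lower number from compound 1 to compound 2 (0.22 log units; within the scatter). Compound 3 gives 1000 nM in this assay; how its core differs from that of compound 1 is not broken down here. Compound 4 `CCCCCCOc1cc2oc(-c3ccccc3)cc(=O)c2c(OC)c1OCCCCCC` is not yet measured and differs from compound 3 by methyl in place of hydrogen on an oxygen on an aromatic ring, the same change as that from compound 1 to compound 2, at the same kind of place. For this assay the expected step is a 1.3-fold lower number from compound 3 to compound 4 (0.12 log units; within the scatter). This expectation rests on a 1.7-fold lower number from compound 1 to compound 2 (0.22 log units; within the scatter), which lies within the scatter. Compound 4 is therefore expected to give about 750 nM, likely between 350 nM and 1800 nM.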

Compound 4, half-maximal effective concentration: 1300 nM
For compound 4 the middle estimate is 1.7-fold (0.24 log units) below the measured one; low and high end bracket the measured number.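

In this assay the methyl in place of hydrogen on an oxygen on an aromatic ring gave a 1.3-fold higher number from compound 3 to compound 4 (0.11 log units; within the scatter) on the core of compound 3. Set beside the earlier step, the two do not differ beyond what repeated measurement allows: the same change on two cores in this assay, a 1.7-fold lower number (0.22 log units; within the scatter) from compound 1 to compound 2 and a 1.3-fold higher number (0.11 log units; within the scatter) from compound 3 to compound 4, 2.2-fold (0.34 log units) apart, within the scatter of two such steps. The change can thus be carried from one core to the other with no detectable difference, but each step itself lies within the scatter, so this does not show that the change has an effect on either core or that the two cores respond alike.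

The compounds shown leave open whether a larger change at this oxygen would have a readable effect on either core. An amine or a carboxylic acid in place of the methyl, or a longer chain there, could test this.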